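This account rests on a few compounds, and the source may have more. Where it says the series, first, only, none or still open, it means among the compounds named here.

compound 1 `COc1ccc(/C=C2\CN(C)C/C(=C\c3ccccc3F)C2=O)cc1` gives 12300 nM
compound 2 `COc1cc(/C=C2\CN(C)C/C(=C\c3ccccc3F)C2=O)cc(OC)c1` gives 1240 nM
compound 3 `CN1C/C(=C\c2cccc([N+](=O)[O-])c2)C(=O)/C(=C/c2ccccc2F)C1` gives 1080 nM

All three values come from a functional assay on HepG2 cells (Homo sapiens) for cytotoxicity, read by MTT assay, with a stated time of 24 h (on this read-out lower numbers stand for stronger inhibition and higher numbers for weaker inhibition), and share one core. Compound 1 has the highest number of the three, so it is the weakest here, and its gaps to compound 2 and to compound 3 both lie beyond the scatter. Compound 2 and compound 3 sit within the scatter of each other.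

Next is compound 4 `CN1C/C(=C\c2ccc(C#N)cc2)C(=O)/C(=C/c2ccccc2F)C1`, which differs from compound 1 as follows: cyano in place of methoxy on an aromatic carbon with cyano in place of methoxy on an aromatic carbon, para to a large group. Within the data shown here, no measured pair isolates a single change. The expectation rests on compound 2 (1240 nM) and compound 3 (1080 nM), which differ from compound 1 on the same aromatic ring and both give lower numbers. Among the measured compounds shown here, with only three compounds, this basis is thin.

The expected change is a 6.8-fold lower number from compound 1 to compound 4 (0.83 log units; beyond the scatter) toward a lower number, beyond the scatter. Compound 4 is estimated at 1800 nM with an expected range from 600 nM to 6000 nM in this assay.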

Compound 4, half-maximal inhibitory concentration: 590 nM
For compound 4 the middle estimate is 3.1-fold (0.48 log units) above the measured one, outside the stated range (below it).
By their numbers in this assay, from the lowest: compounds 4, 3 and 2 (each within the scatter of the next, the first and the last beyond it); then compound 1.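

In this assay the series now has its first readable single-place change: cyano in place of methoxy on an aromatic carbon, para to a large group, gives a 21-fold lower number from compound 1 to compound 4 (1.32 log units; beyond the scatter), a large step beyond the scatter. Compounds 2 and 3 differ from compound 1 in more than one respect, whereas this pair ties the drop to this one place, with the rest of the structure unchanged and the same count of heavy atoms in the entering and leaving groups. Nothing available here accounts for the size of this step.

From the compounds shown here alone, whether this step is specific to cyano remains open, and an amine or a carboxylic acid at this same place would test that. Also open, going by these compounds, is whether the same exchange keeps its size on a different core.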